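The source may report more compounds than this note shows. Statements on the series, on what has been measured and on what is new or still open speak of the compounds shown alone.

Measured compounds:
- compound 1 `CC(C)C(CC1C(=O)NC(=O)N1C)c1ccc(-c2ccc3cccc(F)c3c2)[nH]c1=O`: 0.153 h
- compound 2 `CCC(/C=C1\OC(=O)NC1=O)(CC)c1ccc(-c2ccc3cccc(C(F)(F)F)c3c2)[nH]c1=O`: 0.353 h

Two compounds have been run in an ADME assay on microsomes from liver (Homo sapiens) for metabolic stability (on this read-out lower numbers stand for a shorter-lived compound and higher numbers for a longer-lived compound), so far. Compound 1 gives 0.153 h and stands lowest of the two numbers; the nearest, compound 2, gives 0.353 h, a higher number by a gap that lies beyond the usual scatter. For the measured compounds named here, no step between a pair differing in a single place is available, so the two values can only be read side by side.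

Compound 3 `C/C(=C1/OC(=O)NC1=O)C(c1ccc(-c2ccc3cccc(F)c3c2)[nH]c1=O)C(C)C` has not yet been measured. It differs from compound 1 in one place: a group of 9 heavy atoms (5 carbon, 1 nitrogen, 3 oxygen; one five-membered non-aromatic ring with 2 hetero atoms) in place of a group of 9 heavy atoms (5 carbon, 2 nitrogen, 2 oxygen; one five-membered non-aromatic ring with 2 hetero atoms), on a saturated chain carbon bound to an aromatic carbon and a saturated chain carbon. The leaving group carries two nitrogen and two oxygen atoms, the entering group one nitrogen and three oxygen atoms with one more double bond outside aromatic rings and one more hydrogen-bond acceptor.

Going by the values given here, with no measured step of this kind, a small move is expected, if any, in the direction of a longer-lived compound, and it may well stay within the scatter. The half-life of compound 3 in this assay is estimated at 0.24 h, within 0.11 h to 0.52 h, which would mean a step of a 1.6-fold higher number from compound 1 to compound 3 (0.20 log units; within the scatter) from the measured value of compound 1.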

Compound 3, half-life: > 3 h
Compound 3: no number, only a limit (the forecaster's own chance of this, stated with the estimate: 3%); middle value at least 12-fold (1.09 log units) away from the limit.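

In this assay compound 3 gives > 3 h, which is a limit of the assay and not a number: the limit of > 3 h in this assay, at which 1 of the 3 values shown sits. Replacing the (3-methyl-2,5-dioxoimidazolidin-4-yl)methyl group on the saturated chain carbon bound to an aromatic carbon and a saturated chain carbon gives an at least 19-fold higher number from compound 1 to compound 3 (1.29 log units; beyond the scatter), and the full size of this step cannot be read from a limit. For the compounds shown here, this is the first single-place comparison, and it shows that the half-life can respond strongly to the group at this position while the rest of compound 1 stays unchanged.

The step changes the ring and the double bonds outside aromatic rings together, so the compounds shown do not separate the contribution of the ring from that of the double-bond arrangement. Going by these compounds, it also remains open whether a smaller or differently charged replacement in the same place, such as a carboxylic acid or an amine, would give a similar step, and how far above the limit compound 3 lies.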